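From nitro to hydroxy on an aromatic carbon

The source may report more compounds than this note shows. Statements on the series, on what has been measured and on what is new or still open speak of the compounds shown alone.

Values measured in a functional assay on HCT-15 cells (Homo sapiens) for antiproliferative activity, read by MTT assay, with a stated time of 72 h (on this read-out higher numbers stand for weaker inhibition and lower numbers for stronger inhibition), are these:
Compound 1 `COc1ccc(-n2ccnc2-c2cc(OC)c(OC)c(OC)c2)cc1[N+](=O)[O-]` gives 1000 nM as a number
Compound 2 `COc1cc(-c2nccn2-c2cccc([N+](=O)[O-])c2)cc(OC)c1OC` gives > 100000 nM as a limit

Going by the values given here, compound 1 holds the only actual number in this assay so far. For compound 2 the entry > 100000 nM is a limit of the assay and not a number. Among the compounds with values here, the single measured step is an at least 100-fold higher number from compound 1 to compound 2 (2.00 log units; beyond the scatter) and it comes with hydrogen in place of methoxy on an aromatic carbon.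

Compound 3 `COc1ccc(-n2ccnc2-c2cc(OC)c(OC)c(OC)c2)cc1O` is compound 1 with hydroxy in place of nitro on an aromatic carbon and this place is ortho to a methoxy group. Within the data shown here, no measured compound carries the hydroxy, so the measured step gives no direct size for this change. Compound 3 keeps the methoxy group, however, so a loss on the scale of an at least 100-fold higher number from compound 1 to compound 2 (2.00 log units; beyond the scatter) is not expected here. A moderate move towards stronger inhibition is expected instead, with wide uncertainty. The expected change is a 5.0-fold lower number from compound 1 to compound 3 (0.70 log units; beyond the scatter) in this assay on this estimate. Compound 3 is estimated at 200 nM with an expected range from 15 nM to 2500 nM in this assay when it is measured.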

Compound 3, half-maximal inhibitory concentration: 200 nM
Compound 3: the middle estimate sits on the measured number at the digits printed; the range from low to high includes it.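

In this assay, replacing nitro with hydroxy, ortho to a methoxy group, gives a 5.0-fold lower number from compound 1 to compound 3 (0.70 log units; beyond the scatter), so nitro is not required at this place for activity and the change brings a modest gain. The exchange is also a large one in what is counted: nitro, with 3 heavy atoms and no hydrogen-bond donors, gives way to hydroxy, with 1 heavy atom and 1 hydrogen-bond donor, and the shared core keeps its activity. Compound 2 remains a limit of the assay and not a number, which leaves the hydroxy step as the only one here with a number at both ends: the limit of > 100000 nM in this assay, at which 1 of the 3 values shown sits.

This single pair cannot separate the loss of nitro from the arrival of hydroxy, and an amine, a plain hydrogen or a second methoxy group at the same place would be needed to tell these apart. It also leaves open whether the gain with hydroxy would persist if the neighbouring methoxy group were replaced by an ethoxy group or by hydrogen.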